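This account rests on a few compounds, and the source may have more. Where it says the series, first, only, none or still open, it means among the compounds named here.

Measured so far in an ADME assay on HEK293 cells (Homo sapiens) for cytotoxicity, with a stated time of 6 h; on this read-out higher numbers stand for lower toxicity in this test and lower numbers for higher toxicity in this test:
- compound 1 `CCCCNc1nc(N)nc2cccc(Cl)c12`: 100 nM
- compound 2 `CCCCNc1nc(N)nc2cccc(OCCOC)c12`: 10000 nM
- compound 3 `CCCCNc1nc(N)nc2cccc(OCc3ccccn3)c12`: > 25000 nM (a limit, not a number)

Compound 3 stands highest of the three, but only as a limit, (the limit of > 25000 nM in this assay, at which 1 of the 3 values shown sits), with no exact number. The next change gives compound 4 `CCCCNc1nc(N)nc2cccc(C(=O)NC(C)C)c12`, namely (isopropylcarbamoyl in place of (pyridin-2-yl)methoxy on an aromatic carbon), isopropylcarbamoyl in place of (pyridin-2-yl)methoxy on an aromatic carbon. All measured steps fall at this same place: a 100-fold higher number from compound 1 to compound 2 (2.00 log units; beyond the scatter) and an at least 250-fold higher number from compound 1 to compound 3 (2.39 log units; beyond the scatter) are both large, while an at least 2.5-fold higher number from compound 2 to compound 3 (0.39 log units; beyond the scatter) is at least modest. Among the compounds with values here, none of the measured compounds carries an amide, so the expectation is loose: a modest to large move to a lower number in this assay, staying well clear of compound 1. The expected step is an at least 3.1-fold lower number from compound 3 to compound 4 (0.49 log units; beyond the scatter), in that direction. The estimate for compound 4 is 8000 nM, with an expected range from 1500 nM to 25000 nM.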

Compound 4, half-maximal cytotoxic concentration: > 25000 nM
Compound 4: a limit, no number; the forecaster's own chance of this, stated with the estimate: 20%; middle value at least 3.1-fold (0.49 log units) away from the limit.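

In this assay, compound 4 stands at a limit, > 25000 nM, and not at a number. Isopropylcarbamoyl in place of 2-methoxyethoxy gives an at least 2.5-fold higher number from compound 2 to compound 4 (0.39 log units; beyond the scatter), and in place of chloro it gives an at least 250-fold higher number from compound 1 to compound 4 (2.39 log units; beyond the scatter), so neither an oxygen link to the aromatic carbon nor a ring in the group is needed for such a high reading. The step between the two compounds at the limit cannot be read: the limit of > 25000 nM in this assay, at which 2 of the 4 values shown sit.

Any order among compound 3 and compound 4 remains open. Also open, as far as these compounds go, is whether an amine or a carboxylic acid on this aromatic carbon would read as far from compound 1.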